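This account rests on a few compounds, and the source may have more. Where it says the series, first, only, none or still open, it means among the compounds named here.

Values as measured in a functional assay on SK-HEP1 cells (Homo sapiens) for antiproliferative activity, read by sulforhodamine B assay, with a stated time of 72 h; a lower number here means a stronger inhibitor, a higher number a weaker inhibitor:
- compound 1 `CCOC(=O)c1cnc2ccc(-c3cnc(OC)c(NS(=O)(=O)c4ccc(F)cc4F)c3)cn12`: 300 nM
- compound 2 `CCOC(=O)c1cnc2ccc(-c3cnc(OC)c(NS(C)(=O)=O)c3)cn12`: 170 nM
- compound 3 `COc1ncc(-c2ccc3ncc(C(=O)N4CCC(OC(=O)c5ccccc5)CC4)n3c2)cc1NS(=O)(=O)c1ccc(F)cc1F`: 2050 nM

Compound 2 and compound 1 lie within the scatter of each other. Compound 3 stands apart from both, with a higher number. Compound 4 `CCCCS(=O)(=O)Nc1cc(-c2ccc3ncc(C(=O)OCC)n3c2)cnc1OC` changes only the group on the sulfonyl sulfur of compound 2, methylsulfonyl to butylsulfonyl: propyl in place of hydrogen on a saturated chain carbon bound to a sulfonyl sulfur.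

Among the measured compounds shown here, the only measured step at this sulfonyl sulfur is a 1.8-fold lower number from compound 1 to compound 2 (0.25 log units; within the scatter), and it stays within the scatter even though methyl takes the place of 2,4-difluorophenyl. For the measured compounds named here, compound 3 offers no step at this sulfonyl sulfur and does not bear on the question. Going by the values given here, no measured compound carries a chain longer than methyl here, so one step is thin support and the range is kept wide. No step beyond the scatter is expected in this assay, and no direction can be called. The expected step is a 1.2-fold higher number from compound 2 to compound 4 (0.07 log units; within the scatter) for now. Compound 4 is estimated at 200 nM, with an expected range of 80 nM to 500 nM as the working bounds.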

Compound 4, half-maximal inhibitory concentration: 830 nM
Compound 4: the middle estimate sits 4.2-fold (0.62 log units) below what was measured; the whole stated range lies below it.
By their numbers in this assay, from the lowest: compounds 2 and 1 (each within the scatter of the next); then compound 4; then compound 3.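

In this assay, the group on the sulfonyl sulfur is shown to matter: the step from methylsulfonyl to butylsulfonyl is beyond the scatter (a 4.9-fold higher number from compound 2 to compound 4 (0.69 log units; beyond the scatter)). The butyl chain also gives a step beyond the scatter when set against the 2,4-difluorophenyl group (a 2.8-fold higher number from compound 1 to compound 4 (0.44 log units; beyond the scatter)), whereas methyl and 2,4-difluorophenyl stayed within the scatter of each other, so the earlier tolerance at this position does not extend to every group. No measurement at hand accounts for this result.

As far as these compounds go, whether the higher number already appears with an ethyl or propyl chain, or grows further with a longer chain such as hexyl, remains open. Also open, from the compounds shown here alone, is how a butyl chain ending in an amine or a carboxylic acid would compare with the plain butyl of compound 4.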